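The source may report more compounds than this note shows. Statements on the series, on what has been measured and on what is new or still open speak of the compounds shown alone.

Measured compounds in a functional assay on A549 cells (Homo sapiens) for cytotoxicity, read by sulforhodamine B assay, with a stated time of 72 h; a lower number here means a stronger inhibitor, a higher number a weaker inhibitor:

compound 1 `CCCCCCCCCC(=O)Nc1ccn([C@@H]2CO[C@H](CO)O2)c(=O)n1` gives 24 nM
compound 2 `CCCCCCCCCCCCCCCCCC(=O)Nc1ccn([C@@H]2CO[C@H](CO)O2)c(=O)n1` gives 25 nM

Compound 2 carries the higher of the two numbers, but only by a 1.0-fold higher number from compound 1 to compound 2 (0.02 log units; within the scatter), so compound 1 and compound 2 stand level in this assay and neither can be called the stronger.

Compound 3 `CCCCCCCCCCCCCCCCCCCC(=O)Nc1ccn([C@@H]2CO[C@H](CO)O2)c(=O)n1` differs from compound 2 by ethyl in place of hydrogen on a saturated chain carbon, ten or more bonds along the chain from a carbonyl carbon. For the measured compounds named here, the one measured step that bears on this change is the chain extension from compound 1 to compound 2, which entered an octyl group at a nearby place on the same chain and gave a 1.0-fold higher number from compound 1 to compound 2 (0.02 log units; within the scatter). That addition is larger than the ethyl now entering, and it moved the number not at all beyond the scatter. On this evidence the step from compound 2 to compound 3 is expected to be flat, no change at the digits printed from compound 2 to compound 3 (within the scatter), with no direction that can be claimed beyond the scatter. The series is thin, two points on one chain, so the range is kept wide.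

Compound 3 is estimated at 25 nM in this assay, within a range of 12 nM to 55 nM.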

Compound 3, half-maximal inhibitory concentration: 30 nM
Compound 3: the middle estimate sits 1.2-fold (0.08 log units) below what was measured, within the range that was stated.
By their numbers in this assay, from the lowest: compounds 1, 2 and 3 (each within the scatter of the next).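

In this assay, ethyl in place of hydrogen on a saturated chain carbon, ten or more bonds along the chain from a carbonyl carbon, gives a 1.2-fold higher number from compound 2 to compound 3 (0.08 log units; within the scatter), so the read-out also stays level at this outer stretch of the chain. Taken over the whole span of the chain, the read-out shows a 1.3-fold higher number from compound 1 to compound 3 (0.10 log units; within the scatter), which means that even this longer extension does not leave the scatter, and the level reading now rests on three chain lengths instead of a single pair. Nothing on hand gives a reason for this level reading.

All three compounds keep the same amide and the same shared core, so the shown data say nothing about a much shorter acyl chain such as butyl, or about a chain carrying an amine or a carboxylic acid. Going by these compounds, whether any change to the chain can move the number beyond the scatter, and whether the amide itself can be replaced by a carbamate or a urea without such a move, stays open.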